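This account rests on a few compounds, and the source may have more. Where it says the series, first, only, none or still open, it means among the compounds named here.

Measured in a functional assay on Vero cells (Chlorocebus sabaeus) for cytotoxicity; a lower number here means that less compound is tolerated, a higher number that more compound is tolerated:
Compound 1 `Cc1cn(CC2(CO)CC2CO)c(=O)[nH]c1=O`: > 500 ug/mL (a limit of the assay, not a number)
Compound 2 `O=c1[nH]c(=O)n(CC2(CO)CC2CO)cc1/C=C/I`: 330 ug/mL

Within the data shown here, compound 2, at 330 ug/mL, holds the only actual number so far. Compound 1 stands at the limit of > 500 ug/mL in this assay, at which 1 of the 2 values shown sits. Compound 3 `C#Cc1cn(CC2(CO)CC2CO)c(=O)[nH]c1=O` differs from compound 2 by ethynyl in place of 2-iodoethenyl on an aromatic carbon. Among the measured compounds shown here, the one measured step at this place on the shared core, an at least 1.5-fold lower number from compound 1 to compound 2 (0.18 log units; that floor lies within the scatter), is small, and its floor stays within the usual scatter. A step beyond the scatter is therefore not expected in this assay. The expected step is a 1.2-fold higher number from compound 2 to compound 3 (0.06 log units; within the scatter). The estimate for compound 3 is 380 ug/mL. The estimated range for compound 3 runs from 130 ug/mL to 750 ug/mL.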

Compound 3, half-maximal cytotoxic concentration: > 500 ug/mL
Compound 3: a limit, no number (the forecaster's own chance of this, stated with the estimate: 40%); middle value at least 1.3-fold (0.11 log units) from the limit.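

In this assay, ethynyl in place of 2-iodoethenyl on this aromatic carbon gives an at least 1.5-fold higher number from compound 2 to compound 3 (0.18 log units; that floor lies within the scatter). Of the three groups at this place, only 2-iodoethenyl gives a number rather than a limit, yet neither readable step has a floor beyond the scatter. Compound 3 now shares a limit of the assay with compound 1, so the step between them cannot be read: the limit of > 500 ug/mL in this assay, at which 2 of the 3 values shown sit.

As far as these compounds go, how far the true values of compound 1 and compound 3 lie past that limit stays open. Also open, from the compounds shown here alone, is whether an amine or a longer chain at this place would give a clearly lower number in this assay.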